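Series notes: amide in place of sulfinyl on the fused core

A few compounds are considered here, and "the series" means these few. Any claim that something is new, unique, unknown or untested is made for them only; others in the source may bear on it.

Two compounds in the set have numbers. Compound 1 `CCCCS(=O)(=O)c1sc2nc(-c3nccs3)cc(-c3cnc(C)n3C)c2c1N` gives in an assay for inhibition of 15-hydroxyprostaglandin dehydrogenase [NAD(+)] (Homo sapiens), read by fluorescence, with a stated time of 15 min, in the presence of a further agent that is not named here (a lower number here means a stronger inhibitor, a higher number a weaker inhibitor), a value of 32 nM. Compound 2 `CCCCCC[S+]([O-])c1sc2nc(-c3cccs3)cc(-c3ccccc3)c2c1N` gives in this assay a value of 18 nM; it carries the lower of the two numbers, but compound 1 sits within the scatter of it, so the two cannot be separated.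

Compound 3 `CCCNC(=O)c1sc2nc(-c3cccs3)cc(-c3ccccc3)c2c1N` has not been measured. It differs from compound 2 in one place: a group of 6 heavy atoms (4 carbon, 1 nitrogen, 1 oxygen; no ring) in place of a group of 8 heavy atoms (6 carbon, 1 oxygen, 1 sulfur; no ring), on an aromatic carbon. The entering propylcarbamoyl brings one hydrogen-bond donor where the leaving group had none.

Going by the values given here, no measured pair differs in one place, so no step size is available to lean on. The expectation is a modest weakening, a step possibly beyond the scatter but not large, a 3.3-fold higher number from compound 2 to compound 3 (0.52 log units; beyond the scatter). For compound 3 in this assay the estimate is 60 nM, with a range from 10 nM to 400 nM.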

Compound 3, half-maximal inhibitory concentration: > 7500 nM
Compound 3: only a limit was reported; the forecaster's own chance of this, stated with the estimate: 5%; middle value at least 120-fold (2.09 log units) from the limit.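

In this assay compound 3 gives > 7500 nM, which is a limit of the assay and not a number. Going by these compounds alone, putting propylcarbamoyl on the aromatic carbon next to the ring sulfur, in place of the sulfinyl-bearing chain, gives an at least 410-fold higher number from compound 2 to compound 3 (2.61 log units; beyond the scatter), a large step and the first reading of a single-place change, showing that inhibition depends strongly on the group held at this position. The size of that step is only a bound, so how far the inhibition falls remains undefined: the limit of > 7500 nM in this assay, at which 1 of the 3 values shown sits.

Within the data shown here, the single pair changes the carbonyl, the amide hydrogen and the chain together, so it cannot assign the loss to any one of them. A tertiary amide without the amide hydrogen, or an amide with a longer chain such as hexyl, would bear on that question.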